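The source may report more compounds than this note shows. Statements on the series, on what has been measured and on what is new or still open speak of the compounds shown alone.

Measured in a functional assay on MCF7 cells (Homo sapiens) for inhibition; on this read-out lower numbers stand for stronger inhibition and higher numbers for weaker inhibition:
compound 1 `CC/C(=C(/c1ccc(/C=C/C(=O)O)cc1)c1cc2ccccc2[nH]1)c1cccc(C(F)(F)F)c1` gives 325 nM
compound 2 `CC/C(=C(/c1ccc(/C=C/C(=O)O)cc1)c1cc2ccccc2[nH]1)c1cccc(OC(F)(F)F)c1` gives 282 nM
compound 3 `CC/C(=C(/c1ccc(/C=C/C(=O)O)cc1)c1cc2ccccc2[nH]1)c1cccc(F)c1C#N` gives 40 nM

Compound 3 stands lowest of the three numbers in this assay; the other two sit well above it, with an 8.1-fold lower number from compound 1 to compound 3 (0.91 log units; beyond the scatter) and a 7.1-fold lower number from compound 2 to compound 3 (0.85 log units; beyond the scatter) both beyond the scatter, while the difference between compound 1 and compound 2, a 1.2-fold lower number from compound 1 to compound 2 (0.06 log units; within the scatter), is within it. So the two groups that carry no nitrile and no ring fluorine end up close to one another, and the 2-cyano-3-fluorophenyl group sets compound 3 apart from both.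

Compound 4 `CC/C(=C(/c1ccc(/C=C/C(=O)O)cc1)c1cc2ccccc2[nH]1)c1ccc(Cl)c(C(F)(F)F)c1` carries the change (4-chloro-3-(trifluoromethyl)phenyl in place of 2-cyano-3-fluorophenyl on a double-bonded chain carbon bound to a double-bonded chain carbon and a saturated chain carbon). For the measured compounds named here, the entering 4-chloro-3-(trifluoromethyl)phenyl shares its trifluoromethyl with the 3-(trifluoromethyl)phenyl of compound 1 and adds a chlorine; no measured step covers that chlorine on its own. Going by the values given here, the steps that bear on the move are an 8.1-fold lower number from compound 1 to compound 3 (0.91 log units; beyond the scatter) and a 7.1-fold lower number from compound 2 to compound 3 (0.85 log units; beyond the scatter): leaving the 2-cyano-3-fluorophenyl for a trifluoro-substituted phenyl has so far meant a higher number in this assay. The expectation is therefore a step back up, roughly undoing that gain, as a 7.0-fold higher number from compound 3 to compound 4 (0.85 log units; beyond the scatter). Compound 4 is estimated at 280 nM, with a range of 100 nM to 800 nM in this assay.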

Compound 4, half-maximal inhibitory concentration: 2200 nM
Compound 4: middle estimate off by 7.9-fold (0.90 log units), on the low side; measured number outside the range, above it.
By their numbers in this assay, from the lowest: compound 3; then compounds 2 and 1 (each within the scatter of the next); then compound 4.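

In this assay, a 55-fold higher number from compound 3 to compound 4 (1.74 log units; beyond the scatter) is the largest step seen so far at this double-bonded chain carbon, so the replacement of 2-cyano-3-fluorophenyl can cost much more than compounds 1 and 2 had indicated. For the compounds shown here, the step of a 6.8-fold higher number from compound 1 to compound 4 (0.83 log units; beyond the scatter) isolates what the earlier compounds could not: chloro in place of hydrogen on an aromatic carbon of the 3-(trifluoromethyl)phenyl gives a higher number beyond the scatter, and a 7.8-fold higher number from compound 2 to compound 4 (0.89 log units; beyond the scatter) places compound 4 clearly above the 3-(trifluoromethoxy)phenyl compound as well. No measurement shown here explains why the added chlorine raises the number.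

Still open, from the compounds shown here alone, is whether the nitrile or the fluorine of the 2-cyano-3-fluorophenyl group accounts for the low number of compound 3, as the two appear only together in these compounds. Also open, going by these compounds, is whether the rise in compound 4 is specific to chlorine or would also follow a methyl or methoxy group in its place, and whether it would persist on a ring carrying a nitrile instead of trifluoromethyl.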